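Fluoro for methoxy at the top of the scale

A few compounds are considered here, and "the series" means these few. Any claim that something is new, unique, unknown or untested is made for them only; others in the source may bear on it.

Three compounds share one core. In a functional assay on HL-60 cells (Homo sapiens) for inhibition, read by CCK-8 assay, with a stated time of 48 h, tested at 20 uM (a higher number here means more inhibition of growth at the concentration tested, a lower number less inhibition of growth), compound 1 `COc1ccc(S(=O)(=O)Oc2ccccc2/C=C(\C#N)C(=O)Nc2nnc(-c3cccs3)s2)cc1` gives 67%, compound 2 `COc1ccc(S(=O)(=O)Oc2ccccc2/C=C(\C#N)C(=O)Nc2nnc(Cc3cccc4ccccc34)s2)cc1` gives 98%, and compound 3 `COc1ccc(S(=O)(=O)Oc2ccccc2/C=C(\C#N)C(=O)Nc2nnc(Cc3ccc(F)cc3)s2)cc1` gives 100%. The top two stand level: a number 2 percentage points higher from compound 2 to compound 3 (within the scatter). Both sit well clear of the thiophen-2-yl compound: a number 31 percentage points higher from compound 1 to compound 2 (beyond the scatter) and a number 33 percentage points higher from compound 1 to compound 3 (beyond the scatter).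

Compound 4 `N#C/C(=C\c1ccccc1OS(=O)(=O)c1ccc(F)cc1)C(=O)Nc1nnc(Cc2ccc(F)cc2)s1` keeps everything in compound 3 except one group: fluoro in place of methoxy on an aromatic carbon, para to a large group (fluoro in place of methoxy on an aromatic carbon). Among the compounds with values here, none of the measured steps touches this group. All three exchange thiophen-2-yl, (naphthalen-1-yl)methyl and 4-fluorobenzyl, so they give no direct size for this change. Within the data shown here, they show only that one exchange on this core can move the number greatly while another leaves it within the scatter. With compound 3 at 100%, the number has room to move only downward. The expected change is small and downward, a number 7 percentage points lower from compound 3 to compound 4 (within the scatter). Compound 4 is estimated at 93%, within an expected range from 75% to 100%.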

Compound 4, percent growth inhibition at one concentration: 13%
Estimate against measurement, compound 4: 80 percentage points above; the whole stated range lies above it.
By their numbers in this assay, from the lowest: compound 4; then compound 1; then compounds 2 and 3 (each within the scatter of the next).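

The methoxy group in the (4-methoxyphenyl)sulfonyl part turns out to matter greatly: in this assay, exchanging it for fluoro gives a number 87 percentage points lower from compound 3 to compound 4 (beyond the scatter) on the shared core. Within the data shown here, the earlier steps exchanged only thiophen-2-yl, (naphthalen-1-yl)methyl and 4-fluorobenzyl, so this is the first sign that growth inhibition also depends on the group at this second place, where one small group replacing another is enough to lose most of the effect. Nothing available here explains the loss.

Only methoxy and fluoro are shown at this place, so it remains open whether fluoro harms the effect or methoxy is specifically needed; a hydroxy group, a methyl group, a chloro group or an amine there would help to separate the two. As far as these compounds go, it is also open whether the same exchange would have a similar effect with thiophen-2-yl or (naphthalen-1-yl)methyl in place of 4-fluorobenzyl.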